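Methyl added to compound 3: expected potency

The source may hold more compounds than are shown below. What is called first, only, known or untested is meant among the compounds shown, and "the series" means these compounds.

Compound 1 `NC(=O)c1nn(C2O[C@H](CO)[C@@H](O)[C@H]2O)cc1Br` and compound 3 `NC(=O)c1nn(C2O[C@H](CO)[C@@H](O)[C@H]2O)cc1N` share one core and differ at a single aromatic carbon. In a functional assay on L1210 cells (Mus musculus) (a higher number here means a weaker inhibitor, a lower number a stronger inhibitor), compound 1 gives only a limit of the assay, > 1550 uM. Compound 3 likewise gives only a limit in this assay, > 1830 uM. The step that the two limits leave unreadable from compound 1 to compound 3 therefore cannot be read, since both ends sit at limits (the limit of > 1550 uM in this assay, at which 1 of the 3 values shown sits, (the limit of > 1830 uM in this assay, at which 1 of the 3 values shown sits)). Compound 2 `Cc1c([N+](=O)[O-])c(C(N)=O)nn1C1O[C@H](CO)[C@@H](O)[C@H]1O` carries a methyl and a nitro group; in this assay compound 2 also gives only a limit, > 1650 uM (the limit of > 1650 uM in this assay, at which 1 of the 3 values shown sits). Compound 3 thus stands where every measured compound stands: at a limit, with no number beyond it. Compound 4 `Cc1c(N)c(C(N)=O)nn1C1O[C@H](CO)[C@@H](O)[C@H]1O` differs from compound 3 by methyl in place of hydrogen on an aromatic carbon. For the measured compounds named here, no measured step bears on this change, and the single measured step is itself unreadable; nothing measured here gives a direction. The methyl is expected to leave compound 4 at or near the same limit, a step that the limit leaves unreadable from compound 3 to compound 4 not expected to exceed the scatter. Compound 4 is therefore estimated at 2000 uM, in the range 700 uM to 6000 uM, and most likely reported again only as a limit.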

Compound 4, concentration for 50% inhibition: > 1840 uM
Compound 4: only a limit was reported; the forecaster's own chance of this, stated with the estimate: 85%; the middle value lies beyond the limit too.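

In this assay compound 4 gives only a limit of > 1840 uM and no number beyond it. Neither step to compound 4, from compound 3 or from compound 2, can be read, as both ends of each are limits. The compounds shown leave open what potency any of them has in this assay and whether any of these changes on the shared core alters it.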